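The source may hold more compounds than are shown below. What is called first, only, known or untested is meant among the compounds shown, and "the series" means these compounds.

Series notes: aspirin-type esters carrying nitrooxy groups on the acyl chain, compared for partition behaviour.

Compound 1 `O=C(CCCO[N+](=O)[O-])Oc1ccccc1C(=O)O` gives 1.6 in a physicochemical assay for lipophilicity; a lower number here means a more polar compound, a higher number a more lipophilic compound. Compound 2 `O=C(CCCCC(CO[N+](=O)[O-])O[N+](=O)[O-])Oc1ccccc1C(=O)O` gives 1.6 in this assay. Compound 3 `CC(C)(CO[N+](=O)[O-])C(=O)Oc1ccccc1C(=O)O` gives 1.6 in this assay. At the digits reported, compound 2 stands level with compound 1 and compound 3, and its gaps to both lie within the scatter of this assay, so no order among the three can be read from these numbers.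

Compound 4 `O=C(CCCCCCO[N+](=O)[O-])Oc1ccccc1C(=O)O` has not yet been measured. Relative to compound 2 it differs in one place: hydrogen in place of nitrooxy on a saturated chain carbon bound to two saturated chain carbons. The nitrooxy leaves and hydrogen enters on the saturated chain carbon.

For the measured compounds named here, no step between two measured compounds isolates this change. The expectation rests on the three measured values sitting together despite differing numbers of nitrooxy groups and chain lengths. A small rise in this assay from compound 2 to compound 4 is expected, of a size a number 0.30 log units higher from compound 2 to compound 4 (within the scatter) that may not clear the scatter.

For compound 4 the estimated value is 1.9, with a range from 1.4 to 2.4.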

Compound 4, partition coefficient: 1.6
Beside the measured number, compound 4's estimate is 0.30 log units above it; the measured number falls inside the stated range.
By their numbers in this assay, from the lowest: compounds 1, 2, 3 and 4 (each within the scatter of the next).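

Hydrogen in place of nitrooxy on a saturated chain carbon bound to two saturated chain carbons can now be read directly in this assay, which gives no change at the digits printed from compound 2 to compound 4 (within the scatter) and provides a one-place step that the earlier compounds lacked. 3-(nitrooxy)propyl in place of nitrooxy on a saturated chain carbon, three bonds along the chain from a carbonyl carbon, gives no change at the digits printed from compound 1 to compound 4 (within the scatter) in this assay, so neither change separates the compounds at this resolution. No supporting data bear on this result.

On these data alone, whether an amine or a hydroxyl group on the saturated chain carbon would give a different reading in this assay remains open. As far as these compounds go, it is also open whether a longer chain than that of compound 4 would leave the number in the same place.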